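The compounds below may be only part of what the source reports. "The series", "measured", "known", "first", "only" and "open" are said of these compounds alone.

Measured compounds in a functional assay on A2780 cells (Homo sapiens) for cytotoxicity, read by MTT assay, with a stated time of 72 h; on this read-out lower numbers stand for stronger inhibition and higher numbers for weaker inhibition:
Compound 1 `CN1[C@@H]2c3[nH]c4ccccc4c3C[C@H]1[C@H](C#N)N1[C@@H](CNC(=O)c3ccc(Cl)cc3)c3[nH]c4ccccc4c3C[C@@H]21` gives 230 nM.
Compound 2 `CCc1ccc(C(=O)NC[C@H]2c3[nH]c4ccccc4c3C[C@H]3[C@H]4c5[nH]c6ccccc6c5C[C@@H]([C@H](C#N)N23)N4C)cc1` gives 670 nM.
Compound 3 `CN1[C@@H]2c3[nH]c4ccccc4c3C[C@H]1[C@H](C#N)N1[C@@H](CNC(=O)c3cccc4c3CCCC4)c3[nH]c4ccccc4c3C[C@@H]21` gives 810 nM.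

Compound 3 carries the highest number of the three in this assay; compound 2 sits within the scatter of it, while compound 1 is clearly lower, as seen in a 3.5-fold higher number from compound 1 to compound 3 (0.55 log units; beyond the scatter). Compound 4 `CN1[C@@H]2c3[nH]c4ccccc4c3C[C@H]1[C@H](C#N)N1[C@@H](CNC(=O)c3ccc4ccccc4c3)c3[nH]c4ccccc4c3C[C@@H]21` keeps the shared core and changes only the group on the carbonyl carbon: naphthalen-2-yl in place of 1,2,3,4-tetrahydronaphthalen-5-yl on a carbonyl carbon.

Going by the values given here, the steps that bear on this are the two earlier swaps at the same carbonyl carbon. a 3.5-fold higher number from compound 1 to compound 3 (0.55 log units; beyond the scatter) was modest; a 1.2-fold higher number from compound 2 to compound 3 (0.08 log units; within the scatter) stayed within the scatter. Both bicyclic groups, the one that leaves and the one that enters, have the same count of heavy atoms and no donors or acceptors, so there is no basis here for a step beyond the scatter in either direction in this assay. The step from compound 3 to compound 4 is therefore expected to be about a 1.2-fold lower number from compound 3 to compound 4 (0.06 log units; within the scatter). Compound 4 is estimated at 700 nM, with a range from 300 nM to 1600 nM.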

Compound 4, half-maximal inhibitory concentration: 1030 nM
Compound 4: the middle estimate sits 1.5-fold (0.17 log units) below what was measured; the range from low to high includes it.
By their numbers in this assay, from the lowest: compound 1; then compounds 2, 3 and 4 (each within the scatter of the next).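

In this assay, a second aromatic ring in place of the non-aromatic one on the carbonyl carbon, with the same count of heavy atoms, leaves the number unresolved: a 1.3-fold higher number from compound 3 to compound 4 (0.10 log units; within the scatter). The same holds against the single-ring 4-ethylphenyl group, with a 1.5-fold higher number from compound 2 to compound 4 (0.19 log units; within the scatter), so compounds 2, 3 and 4 now form one group within the scatter, while the 4-chlorophenyl group of compound 1 stays apart from all three, including a 4.5-fold higher number from compound 1 to compound 4 (0.65 log units; beyond the scatter). No measurement at hand accounts for this separation of compound 1.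

On these data alone, it remains open whether the separation belongs to the chloro group itself, which a 4-bromophenyl or 4-methoxyphenyl group on the same carbonyl carbon would help to test. The compounds shown also leave open how a group carrying an amine or a carboxylic acid would read here.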